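Substituent swap on the shared core, agonist read-out

The source may hold more compounds than are shown below. What is called first, only, known or untested is meant among the compounds shown, and "the series" means these compounds.

Compound 2 `CCCS(=O)(=O)Nc1cccc2c1CCC2c1ncc[nH]1` carries a (propylsulfonyl)amino group on the shared core. In a functional assay on CHO cells for agonist activity at Alpha-1D adrenergic receptor (Homo sapiens), read by FLIPR and calcium flux (on this read-out higher numbers stand for an effect only at larger amounts of compound and lower numbers for an effect already at smaller amounts), compound 2 gives only a limit, > 10000 nM. Compound 1 `COc1c(C)ccc2c1CCC2c1ncc[nH]1` shows the same picture: in this assay compound 1 gives > 10000 nM, again a limit. Both values sit at the limit of > 10000 nM in this assay, at which 2 of the 2 values shown sit. Compound 3 `Cn1nccc1-c1cccc2c1CCC2c1ncc[nH]1` is the next step: 1-methyl-1H-pyrazol-5-yl in place of (propylsulfonyl)amino on an aromatic carbon. Within the data shown here, no measured step connects these two groups, so the expected move from compound 2 to compound 3 is none beyond the scatter, a step that the limit leaves unreadable from compound 2 to compound 3. Compound 3 is expected to give 15000 nM, within 3000 nM to 60000 nM, most likely again as a limit.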

Compound 3, half-maximal effective concentration: > 10000 nM
Compound 3: a limit, no number; the forecaster's own chance of this, stated with the estimate: 70%; the middle value does not contradict the limit.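

No step can be read between compound 2 and compound 3, as both stand at a limit and not at a number: the limit of > 10000 nM in this assay, at which 3 of the 3 values shown sit.

The compounds shown leave open whether any group on the shared core gives a measurable value in this assay.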